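Swapping Bromine for Methyl on a Thiosemicarbazone Aryl Group

A few compounds are considered here, and "the series" means these few. Any claim that something is new, unique, unknown or untested is made for them only; others in the source may bear on it.

Measured compounds:
- compound 1, `S=C(N/N=C/c1ccc2ccccc2n1)Nc1ccc(Br)cc1`: 54400 nM
- compound 2, `CN(C)C(=S)N/N=C/c1nc2ccccc2s1`: 250 nM
- compound 3, `FC(F)(F)c1ccccc1NC(=S)N/N=C/c1ccc2ccccc2n1`: 18100 nM

The three measured compounds were tested in a functional assay on HT-29 cells (Homo sapiens) for antiproliferative activity, read by sulforhodamine B assay, with a stated time of 72 h; on this read-out higher numbers stand for weaker inhibition and lower numbers for stronger inhibition. Among them compound 1 gives the highest number, 54400 nM, meaning the weakest inhibition of the three. The nearest is compound 3 at 18100 nM, a gap beyond the usual scatter, and the furthest is compound 2 at 250 nM, which stands far apart from both others and has a different core.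

The unmeasured compound 4, `Cc1ccc(NC(=S)N/N=C/c2ccc3ccccc3n2)cc1`, shares the core of compound 1 and differs from it in one place: methyl in place of bromo on an aromatic carbon. Bromo and methyl are both small single-atom groups with no donors or acceptors, and no measured pair shows what such a swap does on this core. Going by the values given here, the expectation is therefore a modest effect, with a slight lean toward stronger inhibition given that compound 3 already sits lower than compound 1 with a different aryl substituent, though that pair differs in more than one way and carries no computed step. Compound 4 is expected to give about 40000 nM in this assay, within a range of 15000 nM to 110000 nM, an expected step of a 1.4-fold lower number from compound 1 to compound 4 (0.13 log units; within the scatter).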

Compound 4, half-maximal inhibitory concentration: 85500 nM
Compound 4: middle estimate off by 2.1-fold (0.33 log units), on the low side; the range from low to high includes it.
By their numbers in this assay, from the lowest: compound 2; then compound 3; then compounds 1 and 4 (each within the scatter of the next).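

In this assay, going by these compounds alone, putting methyl in place of bromo on an aromatic carbon, para to a large group, gives a 1.6-fold higher number from compound 1 to compound 4 (0.20 log units; within the scatter), and this is the only comparison here in which two compounds differ in just one place. It shows that, on this core, the 4-bromophenyl to 4-methylphenyl change cannot be told apart from ordinary variation between repeated measurements, so compound 1 and compound 4 read alike at this position. Nothing available here accounts for this outcome, which therefore stands as an observation only.

The compounds shown leave open whether a different kind of group at this same position, such as an amine, a carboxylic acid or a longer chain, would move the number beyond the scatter. They also leave open how the trifluoromethyl group of compound 3 and the different core of compound 2 contribute to their numbers, since neither compound differs from compound 1 or compound 4 in only one place.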